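One Shared Core, Two Acid Side Chains, One Unmeasured Step

This account rests on a few compounds, and the source may have more. Where it says the series, first, only, none or still open, it means among the compounds named here.

Compound 2 `O=C(O)CC[C@H](NC(=O)CN(c1nc(Cl)nc2[nH]cnc12)C1CC1)C(=O)O` stands highest of the two compounds measured in a functional assay on the whole organism (Tail, strain ICR) with Mus musculus as the target, in the tail flick test, with a stated time of 90 min, at a dose of 25 umol/kg by the oral route (a lower number here means a weaker effect, a higher number a stronger effect of the compound at the dose given), where compound 2 gives 44.7%. For the measured compounds named here, its only neighbour, compound 1 `C[C@@H](O)[C@H](NC(=O)CN(c1nc(Cl)nc2[nH]cnc12)C1CC1)C(=O)OCc1ccccc1`, gives 29.9% in this assay, a weaker effect by a gap beyond the usual scatter. Compound 3 `C[C@@H](O)[C@H](NC(=O)CN(c1nc(Cl)nc2[nH]cnc12)C1CC1)C(=O)O` has not been measured; it differs from compound 2 by 1-hydroxyethyl in place of 2-carboxyethyl on a saturated chain carbon bound to an amide-type nitrogen and a carbonyl carbon. Going by the values given here, no step between measured compounds isolates this change, so the expectation rests on the two values alone. Compound 3 is expected to land between them, with a downward step a number 11.7 percentage points lower from compound 2 to compound 3 (beyond the scatter) that is expected to exceed the scatter. Compound 3 is accordingly estimated at 33%, ranging from 18% to 48%.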

Compound 3, a percentage reported as activity, at one dose (the size of the read-out at that dose, not a potency): 35.9%
For compound 3 the middle estimate is 2.9 percentage points below the measured one, within the range that was stated.
By their numbers in this assay, from the lowest: compounds 1, 3 and 2 (each within the scatter of the next, the first and the last beyond it).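

In this assay, for the compounds shown here, 1-hydroxyethyl in place of 2-carboxyethyl on a saturated chain carbon bound to an amide-type nitrogen and a carbonyl carbon gives a first direct reading at this position (a number 8.8 percentage points lower from compound 2 to compound 3 (within the scatter)), and the change does not separate the two compounds. Hydrogen in place of benzyl on an oxygen next to a carbonyl group (a number 6 percentage points higher from compound 1 to compound 3 (within the scatter)) likewise leaves its pair unseparated. No measurement here accounts for either step. On these data alone, whether an amine or a longer chain at this position would give a step beyond the scatter remains open.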